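A few compounds are considered here, and "the series" means these few. Any claim that something is new, unique, unknown or untested is made for them only; others in the source may bear on it.

Compound 1 `Cc1ccccc1N(C)C(=O)c1ccc(-c2ccc(OS(N)(=O)=O)c(Cl)c2)o1` in an assay on T47D cells for inhibition of Steryl-sulfatase (Homo sapiens), read by HPLC, with a stated time of 24 h (a higher number here means a weaker inhibitor, a lower number a stronger inhibitor), gives 27 nM. Compound 2 `Cc1cc(-c2ccc(C(=O)N(C)c3ccccc3C)o2)ccc1OS(N)(=O)=O` has no result reported in this assay, where compound 2 shows "nd" (no result reported), so compound 2 stands nowhere on the numbers shown. Compound 3 `Cc1ccccc1N(C)C(=O)c1ccc(-c2ccc(OS(N)(=O)=O)c(F)c2)o1` differs from compound 2 by fluoro in place of methyl on an aromatic carbon. Among the compounds with values here, no measured step covers this change, so the size and direction of the step in this assay cannot be stated; the nearest anchor is compound 1 with a chloro group ortho to the sulfamoyloxy group. Compound 3 is estimated at 40 nM, with a range of 12 nM to 130 nM, expected to sit near compound 1 because compound 1 gives 27 nM.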

Compound 3, half-maximal inhibitory concentration: 17 nM
Compound 3: the middle estimate sits 2.4-fold (0.37 log units) above what was measured; the measured number falls inside the stated range.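

In this assay, fluoro in place of chloro on the aromatic carbon ortho to a sulfamoyloxy group gives a 1.6-fold lower number from compound 1 to compound 3 (0.20 log units; within the scatter), so the two halogens cannot be told apart at this position. The step from compound 2 to compound 3 cannot be read, as compound 2 has no number, and methyl at this position stays unplaced. Nothing shown bears on why the two halogens read alike. Open, on these data alone, is whether a methoxy group or a nitrile at this position would hold the same level, and how the core of compound 1 reads with only hydrogen there.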